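Swapping the propoxy for allyloxy on a weaker amide

The source may report more compounds than this note shows. Statements on the series, on what has been measured and on what is new or still open speak of the compounds shown alone.

Three related amides have been tested in an in vitro assay on HEK-tsA201 cells for antagonist activity at Neuronal acetylcholine receptor; alpha4/beta2 (Homo sapiens), read by fluorescence and calcium flux; on this read-out lower numbers stand for stronger inhibition and higher numbers for weaker inhibition. Compound 1 `C=CCOc1ccc(C(=O)Nc2cccc(C)n2)cc1` gives 6000 nM. Compound 2 `CCCOc1ccc(C(=O)Nc2cccc(C)n2)cc1` gives 7500 nM, and compound 3 `CCCNc1cccc(NC(=O)c2ccc(OCCC)cc2)n1` gives 15400 nM. Two of the steps between them have been measured directly. Going by the values given here, from compound 2 to compound 1 the only change is vinyl in place of ethyl on a saturated chain carbon bound to an oxygen on an aromatic ring, and the result is a 1.3-fold lower number from compound 2 to compound 1 (0.10 log units; within the scatter). From compound 2 to compound 3 the core itself is altered, and the result is a 2.1-fold higher number from compound 2 to compound 3 (0.31 log units; beyond the scatter).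

Compound 4 `C=CCOc1ccc(C(=O)Nc2cccc(NCCC)n2)cc1` has not yet been measured. It differs from compound 3 by vinyl in place of ethyl on a saturated chain carbon bound to an oxygen on an aromatic ring. Among the compounds with values here, this is the same change as the one from compound 2 to compound 1: in both cases the place is a saturated chain carbon bound to an oxygen on an aromatic ring, word for word. What separates the two cores is that in compound 3 and compound 4 there is propylamino in place of methyl on an aromatic carbon, relative to the core shared by compound 1 and compound 2.

The change is being repeated on a compound that sits at the weak end of the three measured numbers. Because the measured instance reads a 1.3-fold lower number from compound 2 to compound 1 (0.10 log units; within the scatter), a step of similar size is expected here as well, which means a 1.3-fold lower number from compound 3 to compound 4 (0.11 log units; within the scatter). Compound 4 is therefore estimated to give about 12000 nM, with the number expected to fall between 6000 nM and 25000 nM.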

Compound 4, half-maximal inhibitory concentration: 14800 nM
Compound 4: middle estimate off by 1.2-fold (0.09 log units), on the low side, within the range that was stated.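

On the core that carries propylamino, the swap of propoxy for allyloxy gives a 1.0-fold lower number from compound 3 to compound 4 (0.02 log units; within the scatter) in this assay, and the same swap on the core of compound 1 and compound 2 also stays within the scatter, so the two cores agree: (the same change on two cores in this assay, a 1.3-fold lower number (0.10 log units; within the scatter) from compound 2 to compound 1 and a 1.0-fold lower number (0.02 log units; within the scatter) from compound 3 to compound 4, 1.2-fold (0.08 log units) apart, within the scatter of two such steps). The second change, propylamino in place of methyl on an aromatic carbon, also carries across, with a 2.5-fold higher number from compound 1 to compound 4 (0.39 log units; beyond the scatter) on the allyloxy side closely matching its size on the propoxy side: (the same change on two cores in this assay, a 2.1-fold higher number (0.31 log units; beyond the scatter) from compound 2 to compound 3 and a 2.5-fold higher number (0.39 log units; beyond the scatter) from compound 1 to compound 4, 1.2-fold (0.08 log units) apart, within the scatter of two such steps). These four compounds show that the two changes behaved consistently in this small set, but they do not show why, and they cannot separate allyloxy from propoxy on either core, nor do they establish that the same would hold on any other core.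

The compounds shown leave open whether a longer chain, such as butyl, or a benzyl group in place of propyl or allyl on the oxygen would produce a step beyond the scatter. They also leave open whether an amine other than propylamino, such as morpholine, would follow the same pattern.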